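Amide in place of acid on the chalcone carboxyl

The compounds below may be only part of what the source reports. "The series", "measured", "known", "first", "only" and "open" are said of these compounds alone.

Going by the values given here, compound 1 `COc1ccc(OC)c(C(=O)/C=C/c2ccc(C(=O)O)cc2)c1` has the higher of the two numbers so far in a functional assay on NTUB1 cells (Homo sapiens) for cytotoxicity, read by MTT assay, with a stated time of 72 h (a lower number here means a stronger inhibitor, a higher number a weaker inhibitor), where compound 1 gives 5700 nM. The nearest neighbour, compound 2 `COc1ccc(OC)c(C(=O)/C=C/c2ccc(C(=O)OC(C)C)cc2)c1`, gives 4420 nM in this assay; a 1.3-fold lower number from compound 1 to compound 2 (0.11 log units; within the scatter) is within the scatter. Compound 3 `CCCNC(=O)c1ccc(/C=C/C(=O)c2cc(OC)ccc2OC)cc1` differs from compound 1 by propylamino in place of hydroxy on a carbonyl carbon. Among the compounds with values here, only the step to compound 2 bears on this, and it stayed within the scatter, so no step beyond the scatter is expected in this assay for compound 3 either. The estimate for compound 3 is 4200 nM, range 1500 nM to 12000 nM, meaning an expected 1.4-fold lower number from compound 1 to compound 3 (0.13 log units; within the scatter).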

Compound 3, half-maximal inhibitory concentration: 2260 nM
For compound 3 the middle estimate is 1.9-fold (0.27 log units) above the measured one, within the range that was stated.
By their numbers in this assay, from the lowest: compounds 3, 2 and 1 (each within the scatter of the next, the first and the last beyond it).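

Propylcarbamoyl in place of carboxy, with propylamino replacing hydroxy on a carbonyl carbon, gives the first step beyond the scatter at this position in this assay: a 2.5-fold lower number from compound 1 to compound 3 (0.40 log units; beyond the scatter). The amide and the isopropyl ester are not separated, with a 2.0-fold lower number from compound 2 to compound 3 (0.29 log units; within the scatter), so only the acid and the amide stand apart. No measurement at hand accounts for this step.

Still open, on these data alone, is whether the step belongs to the amide nitrogen or to the propyl chain, which an unsubstituted amide or a methylamide would test. A longer chain such as hexylamino, or a cyclic amine such as morpholine, would show how far this position tolerates change.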